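Adding a Methyl Group to a Sulfonamide Side Chain

The source may report more compounds than this note shows. Statements on the series, on what has been measured and on what is new or still open speak of the compounds shown alone.

Compound 1 `CC(Cn1cc[n+](C)c1/C=N/O)NS(=O)(=O)C(F)(F)F` and compound 2 `CCC(Cn1cc[n+](C)c1/C=N/O)NS(=O)(=O)C(F)(F)F` share a core and differ by methyl in place of hydrogen on a saturated chain carbon, two bonds along the chain from a sulfonamide nitrogen. In a physicochemical assay for lipophilicity (a higher number here means a more lipophilic compound, a lower number a more polar compound), compound 1 gives -0.82 and compound 2 gives -0.42, so the step is a number 0.40 log units higher from compound 1 to compound 2 (beyond the scatter). Compound 3 `CCN(CCn1cc[n+](C)c1/C=N/O)S(=O)(=O)c1ccccc1` has a different core; the difference between the two cores is not broken down here. In this assay compound 3 gives -1.39, the lowest of the three measured values. Compound 4 `CCCN(CCn1cc[n+](C)c1/C=N/O)S(=O)(=O)c1ccccc1` has not yet been measured and differs from compound 3 by methyl in place of hydrogen on a saturated chain carbon, two bonds along the chain from a sulfonamide nitrogen, the same change as that from compound 1 to compound 2. Because that change gave a number 0.40 log units higher from compound 1 to compound 2 (beyond the scatter), a step of similar size is expected here, namely a number 0.40 log units higher from compound 3 to compound 4 (beyond the scatter). Compound 4 is therefore estimated at -0.99 in this assay, with a range of -1.35 to -0.65.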

Compound 4, distribution coefficient: -0.94
Compound 4: the middle estimate sits 0.05 log units below what was measured; low and high end bracket the measured number.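

In this assay the new step is a number 0.45 log units higher from compound 3 to compound 4 (beyond the scatter) and the earlier one is a number 0.40 log units higher from compound 1 to compound 2 (beyond the scatter), so methyl in place of hydrogen moved the number in the same direction and by a similar amount on both cores. Among the compounds shown here, this is only two pairs on two cores, so it does not show that the change would behave the same way on any other core. No measurement at hand explains the agreement between the two steps.

The compounds shown leave open whether a longer chain, an amine or a carboxylic acid entering at the same place would shift the number in a similar way on both cores.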